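A few compounds are considered here, and "the series" means these few. Any claim that something is new, unique, unknown or untested is made for them only; others in the source may bear on it.

Working notes on the series: in an ADME assay on DU-145 cells (Homo sapiens) for cytotoxicity, read by MTT assay, with a stated time of 72 h (on this read-out lower numbers stand for stronger inhibition and higher numbers for weaker inhibition), compound 1 (`COc1ccc(OC)c(C2=C(c3cc(OC)c(OC)c(OC)c3)C(=O)CC2O[SiH2]C(C)(C)C)c1`) gives 100 ug/mL, the higher of the two numbers so far, while compound 2 (`COc1ccc(C2=C(c3cc(OC)c(OC)c(OC)c3)C(=O)C(O[SiH2]C(C)(C)C)C2)cc1OC(C)C`) gives 6.3 ug/mL. Compound 3 (`CC(=O)OC1C/C(=N/O)C(c2ccccc2)=C1c1ccccc1`) gives > 100 ug/mL, which is a limit and not a number. Compound 4 (`COc1ccc(C2=C(c3cc(OC)c(OC)c(OC)c3)C(=O)CC2O[SiH2]C(C)(C)C)cc1O`) keeps the core of compound 1 and exchanges one aryl group: 3-hydroxy-4-methoxyphenyl in place of 2,5-dimethoxyphenyl on a double-bonded ring carbon. Among the compounds with values here, no measured pair isolates this change, so the expectation rests on compound 2, whose aryl group resembles the entering one and whose value is 6.3 ug/mL. A lower number, beyond the scatter, is expected in this assay: a 17-fold lower number from compound 1 to compound 4 (1.22 log units; beyond the scatter). For compound 4 the estimated value is 6 ug/mL, with an expected range of 0.8 ug/mL to 45 ug/mL.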

Compound 4, half-maximal inhibitory concentration: 75 ug/mL
Beside the measured number, compound 4's estimate is 13-fold (1.10 log units) below it; the measured number lies above the stated range.
By their numbers in this assay, from the lowest: compound 2; then compounds 4 and 1 (each within the scatter of the next).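

In this assay, 3-hydroxy-4-methoxyphenyl in place of 2,5-dimethoxyphenyl on the double-bonded ring carbon gives a 1.3-fold lower number from compound 1 to compound 4 (0.12 log units; within the scatter). At this position, the exchange therefore brings in a hydrogen-bond donor without a shift beyond the scatter, so this aryl exchange alone does not separate the two compounds. Compound 3 remains the only entry given as a limit rather than a number: the limit of > 100 ug/mL in this assay, at which 1 of the 4 values shown sits.

Still open, on these data alone, is whether an amine or a carboxylic acid on this aryl group would move the number. Also open is which structural difference accounts for the value of compound 2.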